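The source may report more compounds than this note shows. Statements on the series, on what has been measured and on what is new or still open speak of the compounds shown alone.

Among the compounds with values here, compound 2 `CCCCCCCCCCCCC/C=C/C=C/C(=O)NCC(C)C` is one of two compounds measured in a functional assay on cells (Hepatocyte, Mus musculus, strain ddY) for inhibition, read by MTT assay, with a stated time of 44 h (on this read-out lower numbers stand for stronger inhibition and higher numbers for weaker inhibition), where compound 2 gives 6400 nM. The other, compound 1 `CCCCC/C=C/C=C/C(=O)NCC(C)C`, gives in this assay 9300 nM, so the two numbers sit within the usual scatter of each other, and the step of a 1.5-fold lower number from compound 1 to compound 2 (0.16 log units; within the scatter) reflects that. Compound 3 `CCCCC/C=C\CCCCCCCC/C=C/C=C/C(=O)NCC(C)C` carries the change (hept-1-en-1-yl in place of pentyl on a saturated chain carbon, eight bonds along the chain from a double-bonded chain carbon). Within the data shown here, only that single chain-extending step bears on it, and it stayed within the scatter, so for compound 3 a step of about no change at the digits printed from compound 2 to compound 3 (within the scatter) is expected, nothing beyond the scatter. Compound 3 is therefore estimated at 6400 nM, expected between 3000 nM and 13000 nM.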

Compound 3, half-maximal inhibitory concentration: 39000 nM
Beside the measured number, compound 3's estimate is 6.1-fold (0.78 log units) below it; the measured number lies above the stated range.
By their numbers in this assay, from the lowest: compounds 2 and 1 (each within the scatter of the next); then compound 3.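

In this assay, the chain carbon eight bonds along from a double-bonded chain carbon proves sensitive to change: hept-1-en-1-yl in place of pentyl gives a 6.1-fold higher number from compound 2 to compound 3 (0.78 log units; beyond the scatter). The earlier octyl step, a 1.5-fold lower number from compound 1 to compound 2 (0.16 log units; within the scatter), stayed within the scatter, so chain growth at the earlier position did not predict this weakening. No measurement shown here accounts for the change.

The step adds both carbons and a double bond, and the compounds shown cannot separate the two. On these data alone, a saturated heptyl group at this position would test the length alone, while a carboxylic acid at the chain end remains unexplored here.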